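Methyl in Place of Chloro: An Estimate for Compound 4

The source may hold more compounds than are shown below. What is called first, only, known or untested is meant among the compounds shown, and "the series" means these compounds.

Of the compounds shown here, three built on one shared core have been tested. In a functional assay on C6 cells (Rattus norvegicus) for cytotoxicity, read by MTT assay, with a stated time of 24 h, tested at 100 ug/mL (a higher number here means a weaker effect of the compound at the concentration tested, a lower number a stronger effect), compound 1 `Cc1ccc(-c2cs/c(=N/NC(=O)CSc3nnnn3-c3ccccc3)n2-c2ccccc2)cc1` gives 28.5%. Compound 2 `O=C(CSc1nnnn1-c1ccccc1)N/N=c1/scc(-c2ccc(Cl)cc2)n1-c1ccccc1` gives 54.3% in this assay, and compound 3 `O=C(CSc1ncccn1)N/N=c1/scc(-c2ccc(Cl)cc2)n1-c1ccccc1` gives 45.5%. The cores of compound 2 and compound 3 differ by pyrimidin-2-yl in place of 1-phenyl-1H-tetrazol-5-yl on a sulfur, a change that made a number 8.8 percentage points lower from compound 2 to compound 3 (within the scatter). Compound 1 differs from compound 2 by methyl in place of chloro on an aromatic carbon, and that change made a number 25.8 percentage points lower from compound 2 to compound 1 (beyond the scatter).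

Compound 4 `Cc1ccc(-c2cs/c(=N/NC(=O)CSc3ncccn3)n2-c2ccccc2)cc1` has not yet been measured. It differs from compound 3 by methyl in place of chloro on an aromatic carbon. The place of this change reads the same, word for word, as the place of the change from compound 2 to compound 1, so it is the same change, seen once before among these compounds.

Because the same change gave a number 25.8 percentage points lower from compound 2 to compound 1 (beyond the scatter) on the neighbouring core, a step of similar size is expected: a number 21.5 percentage points lower from compound 3 to compound 4 (beyond the scatter). Since this rests on a single earlier step, the range is kept wide. Compound 4 is estimated at 24%, between 10% and 40%.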

Compound 4, a percentage reported as activity, at one concentration (the size of the read-out at that concentration, not a potency): 45.9%
The estimate for compound 4 lay 21.9 percentage points below the measured number, outside the stated range (above it).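

In this assay, for the compounds shown here, methyl in place of chloro gave a number 0.4 percentage points higher from compound 3 to compound 4 (within the scatter), so the large step seen with 1-phenyl-1H-tetrazol-5-yl on the sulfur did not carry over to the core with pyrimidin-2-yl there: the same change on two cores in this assay, a number 25.8 percentage points lower (beyond the scatter) from compound 2 to compound 1 and a number 0.4 percentage points higher (within the scatter) from compound 3 to compound 4, 26.2 percentage points apart, beyond the scatter of two such steps The same four compounds can be read through the other change, where pyrimidin-2-yl in place of 1-phenyl-1H-tetrazol-5-yl gave a number 17.4 percentage points higher from compound 1 to compound 4 (beyond the scatter), and this too depends on the core: the same change on two cores in this assay, a number 8.8 percentage points lower (within the scatter) from compound 2 to compound 3 and a number 17.4 percentage points higher (beyond the scatter) from compound 1 to compound 4, 26.2 percentage points apart, beyond the scatter of two such steps Together these show that, in this small set, the effect of each change depends on the group at the other place, but they do not show why, and with only two cores they cannot predict the size of the methyl step on a third.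

The compounds shown leave open what other groups in place of chloro, such as methoxy or an amine, would do on either core. They also leave open whether a group carrying a carboxylic acid on the sulfur would follow either core's behaviour.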